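The compounds below may be only part of what the source reports. "The series", "measured", "known", "first", "only" and "open" are said of these compounds alone.

Measured compounds:
Compound 1, `CN(C)C(=O)c1cc2cnc(Nc3ccc(C(=O)NCCCCCCCN=C=S)cc3)nc2n1C1CCCC1`, giving 73.7%.
Compound 2, `CN(C)C(=O)c1cc2cnc(Nc3ccc(C(=O)NCCCN=C=S)cc3F)nc2n1C1CCCC1`, giving 16.7%.

Among the compounds with values here, in a functional assay on A549 cells (Homo sapiens) for inhibition, read by CCK-8 assay, with a stated time of 72 h, tested at 1 uM (a lower number here means a weaker effect, a higher number a stronger effect of the compound at the concentration tested), compound 2 stands lowest of the two numbers so far. Its nearest neighbour is compound 1, whose value lies well above it, by a gap beyond the usual scatter of this kind of measurement. Within the data shown here, the two measured compounds differ from one another in more than one place, so no single step between them can be read off, and the account says of that pair only what its two values show.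

Compound 3, `CN(C)C(=O)c1cc2cnc(Nc3ccc(C(=O)NCCCCCCN=C=S)cc3F)nc2n1C1CCCC1`, has not yet been measured. It differs from compound 2 in one place: a group of 6 heavy atoms (4 carbon, 1 nitrogen, 1 sulfur; no ring) in place of a group of 3 heavy atoms (1 carbon, 1 nitrogen, 1 sulfur; no ring), on a saturated chain carbon, three bonds along the chain from an amide-type nitrogen. The change lengthens the saturated chain that carries the isothiocyanate and brings compound 3 nearer to compound 1 in that respect, while the fluorine of compound 2 remains.

Among the measured compounds shown here, on these two numbers alone, a rise in this assay is expected for compound 3 compared with compound 2, of a moderate size, a number 33.3 percentage points higher from compound 2 to compound 3 (beyond the scatter), though with wide uncertainty since no single-change step is available. The estimate for compound 3 is 50%, within a range from 20% to 80%.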

Compound 3, a percentage reported as inhibition, at one concentration (the size of the read-out at that concentration, not a potency): -11.8%
For compound 3 the middle estimate is 61.8 percentage points above the measured one, outside the stated range (below it).
By their numbers in this assay, from the lowest: compound 3; then compound 2; then compound 1.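

In this assay the chain that carries the isothiocyanate can now be read through a single change, with the fluorine and the rest of the molecule held constant: the group of 6 heavy atoms in place of the group of 3 heavy atoms gives a number 28.5 percentage points lower from compound 2 to compound 3 (beyond the scatter) and is a modest fall, beyond the scatter. At this saturated chain carbon, three bonds along the chain from an amide-type nitrogen, lengthening the chain therefore lowers the read-out in this one pair, and compound 3 gives -11.8% as a negative reading at the concentration tested. Nothing among the available measurements bears on why the read-out moves in this direction.

Compound 1 differs from compound 2 and from compound 3 in more than one place, so the part played by the fluorine alone cannot be read from these compounds. Also open, as far as these compounds go, is how this assay would read for a longer chain with the fluorine kept, or for an amine in place of the isothiocyanate on the same chain.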